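Halogen swap on the pendant phenyl: expectation for compound 4

The source may hold more compounds than are shown below. What is called first, only, known or untested is meant among the compounds shown, and "the series" means these compounds.

Measured so far in an ADME assay on MCF-10A cells (Homo sapiens) for inhibition, with a stated time of 48 h; a lower number here means a stronger inhibitor, a higher number a weaker inhibitor:
- compound 1, `O=C(Nc1ccc(Cl)cc1)N1CCC[C@H]1c1nc(-c2ccccc2)no1`, gives > 50000 nM, which is a limit of the assay.
- compound 2, `Cc1ccccc1-c1noc([C@@H]2CCCN2C(=O)Nc2ccc(Cl)cc2)n1`, gives > 50000 nM, which is a limit of the assay.
- compound 3, `O=C(Nc1ccc(Cl)cc1)N1CCC[C@H]1c1nc(-c2ccccc2F)no1`, gives > 50000 nM, which is a limit of the assay.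

Compound 3 therefore stands at the limit, not at a number, and the two further values in this assay are limits as well; all three sit at the limit of > 50000 nM in this assay, at which 3 of the 3 values shown sit. Because of this the steps a step that the two limits leave unreadable from compound 1 to compound 3 and a step that the two limits leave unreadable from compound 2 to compound 3 cannot be read in size or direction, and the same holds for a step that the two limits leave unreadable from compound 1 to compound 2.

The unmeasured compound 4, `O=C(Nc1ccc(Cl)cc1)N1CCC[C@H]1c1nc(-c2ccc(Cl)cc2)no1`, differs from compound 3 by 4-chlorophenyl in place of 2-fluorophenyl on an aromatic carbon. Among the compounds with values here, the two measured steps that touch this aromatic carbon, from compound 1 to compound 3 and from compound 2 to compound 3, are both unreadable, so no size of step can be derived from them; the change to compound 4 is estimated to leave the result at the limit again, and the expected step is a step that the limit leaves unreadable from compound 3 to compound 4. For compound 4 in this assay the estimate is 100000 nM, within 30000 nM to 300000 nM.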

Compound 4, half-maximal inhibitory concentration: > 50000 nM
Compound 4 was reported as a limit (the forecaster's own chance of this, stated with the estimate: 85%); the middle value is on the limit's open side.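

In this assay compound 4 gives > 50000 nM as a limit of the assay. No step among compound 1, compound 2, compound 3 and compound 4 can be read, because all of their values sit at one limit: the limit of > 50000 nM in this assay, at which 4 of the 4 values shown sit.

In this assay the compounds shown leave open whether phenyl, 2-methylphenyl, 2-fluorophenyl and 4-chlorophenyl differ at all.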